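Bromo to Nitro on the Far Aryl Ring

The source may hold more compounds than are shown below. What is called first, only, known or untested is meant among the compounds shown, and "the series" means these compounds.

Compound 1 `CC(c1ccc(-c2ccccc2)c(F)c1)c1nnc2n1N=C(c1ccc(OC(F)(F)F)cc1)CS2` gives 8400 nM in a functional assay on Huh-7 cells (Homo sapiens) for inhibition, read by sulforhodamine B assay, with a stated time of 72 h; on this read-out lower numbers stand for stronger inhibition and higher numbers for weaker inhibition.
Compound 2 `CC(c1ccc(-c2ccccc2)c(F)c1)c1nnc2n1N=C(c1ccc(C(F)(F)F)cc1)CS2` gives 9400 nM in this assay.
Compound 3 `CC(c1ccc(-c2ccccc2)c(F)c1)c1nnc2n1N=C(c1ccc(Br)cc1)CS2` gives 5000 nM in this assay.

The three measured compounds share one core and differ only in the group on the outer phenyl ring. Compound 3 has the lowest of the three numbers, yet its gap to the others is small: a 1.7-fold lower number from compound 1 to compound 3 (0.23 log units; within the scatter) and a 1.9-fold lower number from compound 2 to compound 3 (0.27 log units; within the scatter), so the three sit together rather than in a clear order. The swap between compound 1 and compound 2 is smaller still, a 1.1-fold higher number from compound 1 to compound 2 (0.05 log units; within the scatter).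

Compound 4 `CC(c1ccc(-c2ccccc2)c(F)c1)c1nnc2n1N=C(c1ccc([N+](=O)[O-])cc1)CS2` carries the change (nitro in place of bromo on an aromatic carbon). For the measured compounds named here, no measured step shows nitro directly, but the three steps already seen, all exchanging one group at this same position, stayed inside the scatter. On that basis the step from compound 3 to compound 4 is expected to be about a 1.2-fold higher number from compound 3 to compound 4 (0.08 log units; within the scatter), that is, no change beyond the scatter in this assay. Compound 4 is therefore estimated at 6000 nM, with a range from 2500 nM to 15000 nM.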

Compound 4, half-maximal inhibitory concentration: 4300 nM
Compound 4: middle estimate off by 1.4-fold (0.14 log units), on the high side, within the range that was stated.
By their numbers in this assay, from the lowest: compounds 4, 3, 1 and 2 (each within the scatter of the next, the first and the last beyond it).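

Nitro puts three heavy atoms and two hydrogen-bond acceptors where bromo had one heavy atom and no acceptors, yet in this assay the exchange of 4-bromophenyl for 4-nitrophenyl gives a 1.2-fold lower number from compound 3 to compound 4 (0.07 log units; within the scatter) and so leaves the reading where it was. The same nitro group also gives the first step among these compounds to pass the scatter, though only modestly: a 2.2-fold lower number from compound 2 to compound 4 (0.34 log units; beyond the scatter) on this read-out, while a 2.0-fold lower number from compound 1 to compound 4 (0.29 log units; within the scatter) stays inside it, so compound 2 and compound 4 are the only pair here that can be told apart. This position therefore accepts four quite different groups with little movement in the numbers, and nothing in the data shown explains the one separated pair.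

Going by these compounds, it remains open whether an amine or a carboxylic acid at this place would stay within the same narrow band, and whether a longer chain, such as a butoxy group, would do so too. All four compounds share the rest of their structure, so they cannot show how much the numbers would move with a change elsewhere on the shared core.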